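Adding a dichlorophenyl thiourea to the ring nitrogen of compound 1

The source may report more compounds than this note shows. Statements on the series, on what has been measured and on what is new or still open speak of the compounds shown alone.

For the measured compounds named here, compound 1 `NC(=O)c1c(NC(=O)c2ccccc2Cl)sc2c1CCNC2` is tested in a functional assay on HeLa cells (Homo sapiens) for antiproliferative activity, with a stated time of 24 h (a lower number here means a stronger inhibitor, a higher number a weaker inhibitor), where compound 1 gives 45000 nM, the second highest of the three numbers so far. Compound 2 `NC(=O)c1c(NC(=O)c2ccccc2Cl)sc2c1CCN(Cc1ccccc1)C2` gives 38400 nM, and compound 3 `NC(=O)c1c(NC(=O)c2ccccc2Cl)sc2c1CCN(C(=O)Nc1ccccc1Cl)C2` gives 45400 nM. Neither substitution on that nitrogen moved the number beyond the scatter: a 1.2-fold lower number from compound 1 to compound 2 (0.07 log units; within the scatter), and a 1.0-fold higher number from compound 1 to compound 3 (0.00 log units; within the scatter). Compound 4 `NC(=O)c1c(NC(=O)c2ccccc2Cl)sc2c1CCN(C(=S)Nc1c(Cl)cccc1Cl)C2` differs from compound 1 by a group of 11 heavy atoms (7 carbon, 1 nitrogen, 1 sulfur, 2 chlorine; one six-membered aromatic ring of carbon only) in place of a hydrogen atom, on an amine nitrogen in a ring. Going by the values given here, the step to compound 3 is the nearest precedent, and no change beyond the scatter is expected for compound 4 because a 1.0-fold higher number from compound 1 to compound 3 (0.00 log units; within the scatter). The expected step is a 1.1-fold lower number from compound 1 to compound 4 (0.03 log units; within the scatter). Compound 4 is therefore estimated at 42000 nM, with a range from 15000 nM to 120000 nM.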

Compound 4, half-maximal inhibitory concentration: 26500 nM
The estimate for compound 4 lay 1.6-fold (0.20 log units) above the measured number, and the stated range covers the measured number.
By their numbers in this assay, from the lowest: compounds 4, 2, 1 and 3 (each within the scatter of the next).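

In this assay, the group of 11 heavy atoms on the amine nitrogen in a ring also stays within the scatter of every earlier substituent (a 1.7-fold lower number from compound 1 to compound 4 (0.23 log units; within the scatter); a 1.7-fold lower number from compound 3 to compound 4 (0.23 log units; within the scatter); a 1.4-fold lower number from compound 2 to compound 4 (0.16 log units; within the scatter)). This position has now carried hydrogen, benzyl, (2-chlorophenyl)carbamoyl and this larger group, with no step beyond the scatter. Nothing available here accounts for these numbers.

Sulfur in place of oxygen cannot be separated from the added chlorine in compound 4. On these data alone, whether an amine or a carboxylic acid on this nitrogen would give a step beyond the scatter remains open.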